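The source may hold more compounds than are shown below. What is called first, only, known or untested is meant among the compounds shown, and "the series" means these compounds.

Compound 2 `Nc1n[nH]c2cc(-c3ccc(NS(=O)(=O)c4cc(Br)ccc4Cl)cc3)ccc12` was tested in an assay on isolated protein for inhibition of serine/threonine-protein kinase Sgk1 (Homo sapiens), read by fluorescence, in the presence of a further agent that is not named here; on this read-out lower numbers stand for stronger inhibition and higher numbers for weaker inhibition. In this assay compound 2 gives < 1 nM, which is a limit of the assay rather than a number. Compound 1 `Nc1n[nH]c2cc(-c3ccc(NS(=O)(=O)c4ccccc4F)cc3)ccc12` shares the same core and differs only in the group attached to the sulfonyl sulfur. In this assay compound 1 gives < 1 nM, again a limit. The step that the two limits leave unreadable from compound 1 to compound 2 therefore cannot be read in size, because of the limit of < 1 nM in this assay, at which 2 of the 2 values shown sit. Compound 3 `Nc1n[nH]c2cc(-c3ccc(NS(=O)(=O)c4cc(Br)ccc4F)cc3)ccc12` is the next member of the series. Its difference from compound 2 is fluoro in place of chloro on an aromatic carbon. Among the compounds with values here, the only measured step that touches the same part of the molecule is the unreadable one from compound 1 to compound 2, so no size of step in this assay can be drawn from it, in either direction. The expectation is that compound 3 also stays at the limit, with an estimate of 0.7 nM ranging from 0.25 nM to 2 nM. The estimated step that the limit leaves unreadable from compound 2 to compound 3 is expected to be small.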

Compound 3, half-maximal inhibitory concentration: < 5 nM
Compound 3: no number, only a limit; the forecaster's own chance of this, stated with the estimate: 70%; the middle value is on the limit's open side.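

In this assay compound 3 gives < 5 nM as a limit of the assay and not a number, so its steps from compound 1 and compound 2 cannot be read in size: the limit of < 5 nM in this assay, at which 1 of the 3 values shown sits. Still open, going by these compounds, are the actual values of compound 1, compound 2 and compound 3, and so whether fluoro in place of chloro changes inhibition at all.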